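Cytotoxicity series: benzyl-to-cyclohexyl change on the core

The compounds below may be only part of what the source reports. "The series", "measured", "known", "first", "only" and "open" are said of these compounds alone.

Measured so far in an ADME assay on HepG2 cells (Homo sapiens) for cytotoxicity, read by luminescence, CellTiter-Glo and ATP content, with a stated time of 72 h; a higher number here means that more compound is needed for the effect, a lower number that less compound is needed:
- compound 1, `COc1ccc(F)cc1CNCCCNc1ccnc2cc(Cc3cc(C)cc(C)c3)ccc12`: 940 nM
- compound 2, `COc1ccc(F)cc1CNCCCNc1ccnc2cc(CC(C)C)ccc12`: 2900 nM
- compound 3, `Cc1cc(C)cc(Cc2ccc3c(NCCCNCc4ccco4)ccnc3c2)c1`: 6270 nM

Compound 3 stands at the highest number of the three. Its gap to compound 2 and its gap to compound 1 are both beyond the scatter, the latter being the step of a 6.7-fold higher number from compound 1 to compound 3 (0.82 log units; beyond the scatter), so compound 3 needs the most compound for the effect among those measured.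

Compound 4, `c1coc(CNCCCNc2ccnc3cc(C4CCCCC4)ccc23)c1`, is not yet measured. It differs from compound 3 in one place: cyclohexyl in place of 3,5-dimethylbenzyl on an aromatic carbon.

Among the measured compounds shown here, the only measured step of a related kind is a 3.1-fold higher number from compound 1 to compound 2 (0.49 log units; beyond the scatter), where an aromatic ring on a saturated chain carbon gave way to a small saturated group. The change from compound 3 to compound 4 is not the same: the whole benzyl group leaves and a saturated ring enters directly on the aromatic carbon of the core. Still, it is the nearest guide available, and it points to a modest rise in the number rather than a fall. A step in this assay of a 2.1-fold higher number from compound 3 to compound 4 (0.32 log units; beyond the scatter) is therefore expected, beyond the scatter but modest.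

Compound 4 is expected to give about 13000 nM in this assay, with a range from 5000 nM to 35000 nM.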

Compound 4, half-maximal effective concentration: 4760 nM
Beside the measured number, compound 4's estimate is 2.7-fold (0.44 log units) above it; the measured number lies below the stated range.
By their numbers in this assay, from the lowest: compound 1; then compounds 2, 4 and 3 (each within the scatter of the next, the first and the last beyond it).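

In this assay, replacing 3,5-dimethylbenzyl with cyclohexyl on the aromatic carbon of the shared core gives a 1.3-fold lower number from compound 3 to compound 4 (0.12 log units; within the scatter), so with the furan-2-yl group held constant, this pair cannot be told apart. The position therefore tolerates this change, which loses the six-membered aromatic ring and goes from 9 heavy atoms to 6, without a shift beyond the scatter. Among the compounds shown here, the only earlier step at this site, a 3.1-fold higher number from compound 1 to compound 2 (0.49 log units; beyond the scatter), lay beyond the scatter, but it exchanged 3,5-dimethylphenyl for isopropyl on the saturated chain carbon with the 5-fluoro-2-methoxyphenyl group in place, so it shows neither a general rule for the position nor a reason for the difference from the new step; nothing measured here explains the new result.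

From the compounds shown here alone, it remains open whether cyclohexyl on the aromatic carbon would behave the same way with the 5-fluoro-2-methoxyphenyl group of compound 1 in place of furan-2-yl. The compounds shown also leave open how the number responds when this position carries a group with a heteroatom, such as a morpholine or a carboxylic acid, rather than a group of carbon only.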